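Farnesyl thioether benzamides: amide variation on compound 2

The source may report more compounds than this note shows. Statements on the series, on what has been measured and on what is new or still open speak of the compounds shown alone.

Measured so far:
compound 1 `CC(C)=CCC/C(C)=C/CC/C(C)=C/CSc1ccccc1C(=O)N(C)C` — 22000 nM
compound 2 `COC(=O)c1ccccc1SC/C=C(\C)CC/C=C(\C)CCC=C(C)C` — 30000 nM

Compound 2 gives the higher of the two numbers in a functional assay on PANC-1 cells (Homo sapiens) for cytotoxicity, with a stated time of 7 days (a higher number here means a weaker inhibitor, a lower number a stronger inhibitor), but the step of a 1.4-fold higher number from compound 1 to compound 2 (0.13 log units; within the scatter) is within the scatter, so no order is claimed. Compound 3 `CC(C)=CCC/C(C)=C/CC/C(C)=C/CSc1ccccc1C(N)=O` carries the change (amino in place of methoxy on a carbonyl carbon). Going by the values given here, the only step that bears on it is the change at the same carbonyl carbon, a 1.4-fold higher number from compound 1 to compound 2 (0.13 log units; within the scatter), which was within the scatter; on that basis compound 3 is expected to show no step beyond the scatter, a 1.2-fold lower number from compound 2 to compound 3 (0.08 log units; within the scatter). Compound 3 is estimated at 25000 nM, with a range from 10000 nM to 60000 nM.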

Compound 3, half-maximal inhibitory concentration: 20000 nM
For compound 3 the middle estimate is 1.3-fold (0.10 log units) above the measured one; the measured number falls inside the stated range.
By their numbers in this assay, from the lowest: compounds 3, 1 and 2 (each within the scatter of the next).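

Amino in place of methoxy on the carbonyl carbon (a 1.5-fold lower number from compound 2 to compound 3 (0.18 log units; within the scatter)) and amino in place of dimethylamino (a 1.1-fold lower number from compound 1 to compound 3 (0.04 log units; within the scatter)) both stay within the scatter in this assay. This position therefore now holds three groups with no resolved order, and the amino group's hydrogen-bond donor brings no separation. No measured evidence accounts for this result. Still open, from the compounds shown here alone, is whether a carboxylic acid or a morpholine amide on this carbonyl carbon would move beyond the scatter, and whether a geranyl chain in place of the farnesyl chain would do so.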